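Para-substituent swap on the aryl ring: ester for trifluoromethyl

The compounds below may be only part of what the source reports. "The series", "measured", "known", "first", "only" and "open" are said of these compounds alone.

Measured compounds:
Compound 1, `NS(=O)(=O)NCC1CCN(c2cc(-c3ccccc3)ncn2)CC1`. In a functional assay on HT-29 cells (Homo sapiens) for antiproliferative activity, read by sulforhodamine B assay, with a stated time of 48 h (on this read-out higher numbers stand for weaker inhibition of growth and lower numbers for stronger inhibition of growth), compound 1 reaches only the assay limit, > 100000 nM.
Compound 2, `CCCCc1ccc(-c2cc(N3CCC(CNS(N)(=O)=O)CC3)ncn2)cc1`. Compound 2 gives 15200 nM.
Compound 3, `NS(=O)(=O)NCC1CCN(c2cc(-c3ccc(C(F)(F)F)cc3)ncn2)CC1`. Compound 3 gives 29100 nM.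

Compound 3 and compound 2 sit within the scatter of each other: a 1.9-fold higher number from compound 2 to compound 3 (0.28 log units; within the scatter). Compound 1, carrying hydrogen at the substituted aromatic carbon, gives only a limit, so both substituted analogues stand apart from it: an at least 6.5-fold lower number from compound 1 to compound 2 (0.81 log units; beyond the scatter) and an at least 3.4-fold lower number from compound 1 to compound 3 (0.53 log units; beyond the scatter). That limit is one of the three values shown, (the limit of > 100000 nM in this assay, at which 1 of the 3 values shown sits).

The unmeasured compound 4, `CCOC(=O)c1ccc(-c2cc(N3CCC(CNS(N)(=O)=O)CC3)ncn2)cc1`, differs from compound 3 by ethoxycarbonyl in place of trifluoromethyl on an aromatic carbon. The two measured steps at this aromatic carbon show that placing either of two quite different groups there gave at least a modest lower number than hydrogen, while the exchange between those two groups stayed within the scatter. Compound 4 keeps a sizeable group at the same place, so the step is expected to stay within the scatter: a 1.2-fold lower number from compound 3 to compound 4 (0.07 log units; within the scatter). Compound 4 is therefore estimated at 25000 nM, with a range from 8000 nM to 80000 nM.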

Compound 4, concentration for 50% growth inhibition: 5700 nM
Estimate against measurement, compound 4: 4.4-fold (0.64 log units) above; measured number below the stated range.
By their numbers in this assay, from the lowest: compound 4; then compounds 2 and 3 (each within the scatter of the next). At a limit, above all of these: compound 1.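

At this aromatic carbon, the identity of the substituent now matters, and not only its presence: in this assay, ethoxycarbonyl stands apart from trifluoromethyl, a 5.1-fold lower number from compound 3 to compound 4 (0.71 log units; beyond the scatter), and from butyl, a 2.7-fold lower number from compound 2 to compound 4 (0.43 log units; beyond the scatter), although the exchange between those two groups stayed within the scatter. Compound 4 has the lowest number of the four, with every step to it beyond the scatter, and the step from hydrogen is now large: an at least 17-fold lower number from compound 1 to compound 4 (1.24 log units; beyond the scatter). Compound 1 stands at a limit, so that last step is a bound and not a measured size: the limit of > 100000 nM in this assay, at which 1 of the 4 values shown sits.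

The compounds shown leave open whether the lower number belongs to the carbonyl or to the ethyl part of the ester. A carboxylic acid, a primary amide or a methyl ester at this carbon would help separate the two.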